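The compounds below may be only part of what the source reports. "The series", "measured", "known", "first", "only" and "open" are said of these compounds alone.

Working notes on the series. Compound 1 `CN(C)CCn1cnnc1-c1cc(Oc2ccc(NC(=O)N/N=C/c3ccc(F)cc3Cl)cc2F)ccn1` is the reference point; in a functional assay on HT-29 cells (Homo sapiens) for cytotoxicity, read by MTT assay, with a stated time of 72 h (a lower number here means a stronger inhibitor, a higher number a weaker inhibitor), compound 1 gives 510 nM, the lowest of the three numbers recorded so far. Compound 3 `CN(C)CCn1cnnc1-c1cc(Oc2ccc(NC(=O)N/N=C/c3c(O)ccc4ccccc34)cc2F)ccn1` stands nearest to it: compound 3 gives 670 nM, and the step of a 1.3-fold higher number from compound 1 to compound 3 (0.12 log units; within the scatter) is within the scatter. Compound 2 `CN(C)CCn1cnnc1-c1cc(Oc2ccc(NC(=O)N/N=C/c3ccc(O)c(F)c3)cc2F)ccn1` stands furthest away: compound 2 gives 3310 nM, and the step of a 6.5-fold higher number from compound 1 to compound 2 (0.81 log units; beyond the scatter) is beyond the scatter, as is the step of a 4.9-fold lower number from compound 2 to compound 3 (0.69 log units; beyond the scatter).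

Compound 4 `CN(C)CCn1cnnc1-c1cc(Oc2ccc(NC(=O)N/N=C/c3ccccc3O[N+](=O)[O-])cc2F)ccn1` varies the same position as compounds 2 and 3, the group on the carbon with a double bond to nitrogen, with the change (2-(nitrooxy)phenyl in place of 2-chloro-4-fluorophenyl on a carbon with a double bond to nitrogen). Both earlier steps from compound 1 bear on it: one exchange at this position left the number essentially unchanged, the other raised it modestly, so this position tolerates some variation but not every group equally. For the measured compounds named here, nothing measured so far involves a 2-(nitrooxy)phenyl group, so the direction rests on the spread of the two earlier steps. A modest weakening, near the middle of that spread, is expected, so the step of a 2.0-fold higher number from compound 1 to compound 4 (0.29 log units; within the scatter) is the estimate. Compound 4 is therefore estimated at 1000 nM, with a range from 350 nM to 3000 nM.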

Compound 4, half-maximal inhibitory concentration: 950 nM
Compound 4: middle estimate off by 1.1-fold (0.02 log units), on the high side; low and high end bracket the measured number.
By their numbers in this assay, from the lowest: compounds 1, 3 and 4 (each within the scatter of the next); then compound 2.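

The 2-(nitrooxy)phenyl group, with 3 hydrogen-bond acceptors and 0 hydrogen-bond donors, shows no separation in this assay from either the 2-chloro-4-fluorophenyl group (a 1.9-fold higher number from compound 1 to compound 4 (0.27 log units; within the scatter)) or the 2-hydroxynaphthalen-1-yl group (a 1.4-fold higher number from compound 3 to compound 4 (0.15 log units; within the scatter)). It does separate from the 3-fluoro-4-hydroxyphenyl group (a 3.5-fold lower number from compound 2 to compound 4 (0.54 log units; beyond the scatter)), so compound 2 now stands apart from all three other compounds, and among these four compounds neither a halogen nor a hydroxyl on the group at this position is needed to stay with compounds 1 and 3, since compound 4 carries neither. No measurement at hand accounts for this grouping.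

The compounds shown do not separate any contribution of the nitrooxy group from that of the phenyl ring carrying it, which a plain phenyl, a 2-methoxyphenyl or a 2-nitrophenyl group at this position would address. They also leave open how an amine or a carboxylic acid on this ring would read in this assay, and whether the grouping holds with any change elsewhere on the core of compound 1.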